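A few compounds are considered here, and "the series" means these few. Any claim that something is new, unique, unknown or untested is made for them only; others in the source may bear on it.

Measured in a functional assay on MCF7 cells (Homo sapiens), read by MTT assay, with a stated time of 48 h; a higher number here means a weaker inhibitor, a lower number a stronger inhibitor:
- compound 1 `CCN(CC)CCNC(=O)c1ccc(C(CC)(CC)c2ccc(OCC(O)C(C)(C)C)c(C)c2)n1CC`: 690 nM
- compound 2 `C#CCNC(=O)c1ccc(C(CC)(CC)c2ccc(OCC(O)C(C)(C)C)c(C)c2)n1CC`: > 50000 nM (a limit, not a number)

Compound 2 stands at the limit of > 50000 nM in this assay, at which 1 of the 2 values shown sits.

Compound 3 `CCn1c(C(=O)NCCN)ccc1C(CC)(CC)c1ccc(OCC(O)C(C)(C)C)c(C)c1` differs from compound 2 in one place, with aminomethyl in place of ethynyl on a saturated chain carbon bound to an amide-type nitrogen.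

Among the measured compounds shown here, one measured step bears on this change: an at least 72-fold higher number from compound 1 to compound 2 (1.86 log units; beyond the scatter). This large step, beyond the scatter, put ethynyl in place of (diethylamino)methyl at that same place. Compound 3 again carries a nitrogen-bearing group there, though without the two ethyl groups of compound 1, which gives 690 nM. A large step to a lower number is therefore expected in this assay, probably stopping short of compound 1.

The expected change is an at least 20-fold lower number from compound 2 to compound 3 (1.30 log units; beyond the scatter).

For compound 3 the estimate is 2500 nM, with an expected range of 500 nM to 15000 nM.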

Compound 3, half-maximal inhibitory concentration: 5.9 nM
Beside the measured number, compound 3's estimate is 420-fold (2.63 log units) above it; the whole stated range lies above it.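

In this assay, this position turns out to be far more sensitive than the first pair showed, since aminomethyl in place of ethynyl gives an at least 8400-fold lower number from compound 2 to compound 3 (3.92 log units; beyond the scatter). Having a nitrogen on the chain is also not the whole story: amino in place of diethylamino, at the same chain carbon, gives a 120-fold lower number from compound 1 to compound 3 (2.07 log units; beyond the scatter), so the groups carried on that nitrogen matter a great deal as well. The first of these steps gives only a minimum size, because compound 2 stands at a limit and not at a number: the limit of > 50000 nM in this assay, at which 1 of the 3 values shown sits.

Going by these compounds, whether a hydroxyl group in place of the amino group would keep this strength stays open, so it is unclear that nitrogen is needed here at all. Also open, on these data alone, is how a methylamino group, or a longer chain carrying the same amino group, would read in this assay.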